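A few compounds are considered here, and "the series" means these few. Any claim that something is new, unique, unknown or untested is made for them only; others in the source may bear on it.

Working notes on the series. The shared core appears in compound 1 `C/C(=C1/OC(=O)NC1=O)C(c1ccc(-c2ccc3cccc(F)c3c2)[nH]c1=O)C(C)C`, compound 2 `CC(C)(/C=C1\OC(=O)NC1=O)c1ccc(-c2ccc3cccc(F)c3c2)[nH]c1=O` and compound 3 `CC(C)/C(=C1\C(=O)NC(=O)N1C)c1ccc(-c2ccc3cccc(F)c3c2)[nH]c1=O`. In a physicochemical assay for solubility, in phosphate buffer, measured as kinetic solubility (a higher number here means a more soluble compound, a lower number a less soluble compound), compound 1 gives 17200 nM, compound 2 gives 36100 nM and compound 3 gives 22500 nM. Compound 1 holds the lowest of the three numbers: its gap to compound 3 is within the usual scatter, so no order between those two can be claimed, while its gap to compound 2 lies beyond the scatter. Among the compounds with values here, no pair of measured compounds differs in a single place, so no measured step guides the next change.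

Compound 4 `CC(C)C(/C=C1\NC(=O)NC1=O)c1ccc(-c2ccc3cccc(F)c3c2)[nH]c1=O` has not yet been measured in this assay. It differs from compound 1 as follows: a group of 8 heavy atoms (4 carbon, 2 nitrogen, 2 oxygen; one five-membered non-aromatic ring with 2 hetero atoms) in place of a group of 9 heavy atoms (5 carbon, 1 nitrogen, 3 oxygen; one five-membered non-aromatic ring with 2 hetero atoms), on a saturated chain carbon bound to an aromatic carbon and a saturated chain carbon. The ring is altered in its hetero atoms and in its donor and acceptor pattern, with no change in net charge and the place on the core kept. With all three measured values falling close together, only a small step is expected, if any, upward rather than downward. For compound 4 the estimated solubility in this assay is 25000 nM, with a range of 9000 nM to 70000 nM, which means an expected step of a 1.5-fold higher number from compound 1 to compound 4 (0.16 log units; within the scatter).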

Compound 4, solubility: 10700 nM
For compound 4 the middle estimate is 2.3-fold (0.37 log units) above the measured one; the range from low to high includes it.
By their numbers in this assay, from the lowest: compounds 4, 1, 3 and 2 (each within the scatter of the next, the first and the last beyond it).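

In this assay the series now has its first readable step: at the saturated chain carbon bound to an aromatic carbon and a saturated chain carbon, exchanging one five-membered non-aromatic ring with 2 hetero atoms for another gives a 1.6-fold lower number from compound 1 to compound 4 (0.21 log units; within the scatter) and so no order can be claimed between the two compounds. At this place, then, a group with 2 hydrogen-bond donors, 2 hydrogen-bond acceptors and one with 1 hydrogen-bond donor, 3 hydrogen-bond acceptors cannot be told apart in this read-out, with no net charge in either. Nothing at hand explains the direction or the size of the step.

As far as these compounds go, whether an open group at this place, such as a carboxylic acid or an amine, would give a step beyond the scatter remains open. Also open, from the compounds shown here alone, is whether the same ring exchange on compound 2 would give a similar step.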